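This account rests on a few compounds, and the source may have more. Where it says the series, first, only, none or still open, it means among the compounds named here.

Measured so far in an assay on isolated protein for activation of cGMP-dependent protein kinase 1 (Homo sapiens), read by ADP-Glo, with stated times of 120 min and 40 min; a higher number here means that more compound is needed for the effect, a lower number that less compound is needed:
- compound 1, `O=C(O)c1ccc2c(CN3CCC[C@H](O[C@H](CO)c4cc(Cl)cc(Cl)c4)[C@@H]3c3ccccc3)c[nH]c2c1`: 22000 nM
- compound 2, `Clc1cc(Cl)cc(CO[C@H]2CCCN(Cc3ccc(-c4nn[nH]n4)cc3)[C@H]2c2ccccc2)c1`: 74000 nM
- compound 3, `OC[C@@H](O[C@H]1CCCN(Cc2ccc(-c3nn[nH]n3)cc2)[C@H]1c1ccccc1)c1cc(Cl)cc(Cl)c1`: 131000 nM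

Compound 3 has the highest number of the three in this assay; against compound 2 it differs only within the scatter (a 1.8-fold higher number from compound 2 to compound 3 (0.25 log units; within the scatter)), while against compound 1 the gap is real (a 6.0-fold higher number from compound 1 to compound 3 (0.77 log units; beyond the scatter)). Compound 4, `O=C(O)c1cncc(CN2CCC[C@H](O[C@H](CO)c3cc(Cl)cc(Cl)c3)[C@@H]2c2ccccc2)c1`, takes the step from compound 3 by 5-carboxypyridin-3-yl in place of 4-(2H-tetrazol-5-yl)phenyl on a saturated chain carbon bound to an amine nitrogen in a ring. Among the measured compounds shown here, the step that bears on this is the one from compound 1 to compound 3, where a carboxy-bearing aromatic group was exchanged for the tetrazolyl-bearing one and the number rose (a 6.0-fold higher number from compound 1 to compound 3 (0.77 log units; beyond the scatter)). Compound 4 brings a carboxy group back, though on a different ring, so the move is expected to run the other way in this assay, with a lower number, and probably not fully back to compound 1. The estimate for compound 4 is 40000 nM, with a range of 12000 nM to 130000 nM, meaning an expected step of a 3.3-fold lower number from compound 3 to compound 4 (0.52 log units; beyond the scatter).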

Compound 4, half-maximal effective concentration: 34000 nM
Compound 4: the middle estimate sits 1.2-fold (0.07 log units) above what was measured; the range from low to high includes it.
By their numbers in this assay, from the lowest: compounds 1 and 4 (each within the scatter of the next); then compounds 2 and 3 (each within the scatter of the next).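

In this assay, among the compounds shown here, at this place on a saturated chain carbon bound to an amine nitrogen in a ring, a carboxy-bearing group again gives a lower number than 4-(2H-tetrazol-5-yl)phenyl (a 3.9-fold lower number from compound 3 to compound 4 (0.59 log units; beyond the scatter)), so the earlier drop no longer rests on the single pair of compound 1 and compound 3. The two carboxy-bearing groups, 5-carboxypyridin-3-yl and 6-carboxy-1H-indol-3-yl, cannot be told apart here (a 1.5-fold higher number from compound 1 to compound 4 (0.19 log units; within the scatter)), which shows that the indole is not required for values in this range. No measurement at hand explains either step.

The compounds shown leave open whether the step follows the carboxylic acid or the ring that carries it, a question that 4-carboxyphenyl at this place would address. From the compounds shown here alone, how a primary carboxamide or a methyl ester would read at this place also remains open.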